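Methoxy to methyl on the side chain of a triazolopyrimidine series

The compounds below may be only part of what the source reports. "The series", "measured", "known", "first", "only" and "open" are said of these compounds alone.

Measured so far:
Compound 1 `CCC(COC)N(C)c1nc(C)nc2c1nnn2-c1ccc(C(C)C)cc1Br`: 11.2 nM
Compound 2 `COCC(COC)N(C)c1nc(C)nc2c1nnn2-c1ccc(C(C)C)cc1Br`: 21.3 nM
Compound 3 `COCCCNc1nc(C)nc2c1nnn2-c1ccc(C(C)C)cc1Br`: 291 nM

All three compounds share one core and were tested in an in vitro assay on 293-EBNA cells for binding affinity to corticotropin-releasing factor receptor 1 (Homo sapiens); a higher number here means a weaker inhibitor, a lower number a stronger inhibitor. Compound 1 and compound 2 differ only in the side chain on the ring nitrogen: methyl in place of methoxy on a saturated chain carbon, two bonds along the chain from a nitrogen on an aromatic ring. That step, a 1.9-fold lower number from compound 2 to compound 1 (0.28 log units; within the scatter), changed little. Compound 3 carries a different side chain on the same aromatic carbon: a group of 6 heavy atoms (4 carbon, 1 nitrogen, 1 oxygen; no ring) in place of a group of 9 heavy atoms (6 carbon, 1 nitrogen, 2 oxygen; no ring), on an aromatic carbon. This change gave a much weaker inhibitor, as shown by a 14-fold higher number from compound 2 to compound 3 (1.14 log units; beyond the scatter) and by a 26-fold higher number from compound 1 to compound 3 (1.41 log units; beyond the scatter).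

Compound 4 `CCCCNc1nc(C)nc2c1nnn2-c1ccc(C(C)C)cc1Br` has not yet been measured. It differs from compound 3 as follows: methyl in place of methoxy on a saturated chain carbon, three bonds along the chain from a nitrogen on an aromatic ring. Within the data shown here, this is the same kind of change as the one from compound 2 to compound 1, with one difference around the place: in the earlier pair the carbon sits two bonds along the chain from a nitrogen on an aromatic ring, whereas here it sits three bonds along the chain from a nitrogen on an aromatic ring. On the pair measured so far, swapping methoxy for methyl moved the value only within the usual scatter, so a similarly small step is expected here, a 1.5-fold lower number from compound 3 to compound 4 (0.16 log units; within the scatter), because compound 3 sits at 291 nM and the earlier step was a 1.9-fold lower number from compound 2 to compound 1 (0.28 log units; within the scatter). The expected value for compound 4 in this assay is therefore 200 nM, with a likely range from 80 nM to 500 nM.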

Compound 4, inhibition constant: 69.6 nM
For compound 4 the middle estimate is 2.9-fold (0.46 log units) above the measured one; the measured number lies below the stated range.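

Set side by side in this assay, the swap of methoxy for methyl gives two results that cannot be told apart, even though only the newer one lies beyond the scatter when read alone: the same change on two cores in this assay, a 1.9-fold lower number (0.28 log units; within the scatter) from compound 2 to compound 1 and a 4.2-fold lower number (0.62 log units; beyond the scatter) from compound 3 to compound 4, 2.2-fold (0.34 log units) apart, within the scatter of two such steps So a 4.2-fold lower number from compound 3 to compound 4 (0.62 log units; beyond the scatter) is a clear step for this pair, but it does not show that the swap acts more strongly on the straight chain than on the branched one. Two pairs are also too few to make a rule for the series, and the swap does not bring the straight chain level with the branched side chains, as a 3.3-fold higher number from compound 2 to compound 4 (0.51 log units; beyond the scatter) and a 6.2-fold higher number from compound 1 to compound 4 (0.79 log units; beyond the scatter) remain.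

The compounds shown leave open how a hydroxyl group, a fluorine atom or an ethoxy group would compare with methoxy and methyl at this place on the chain. They also leave open whether a longer chain such as pentyl, or a side chain closed into a ring such as cyclopentyl, would take the number further from the value of the butyl chain.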